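From 4-chlorophenyl to 2-(4-methoxyphenyl)ethenyl on a shared core

The compounds below may be only part of what the source reports. "The series", "measured", "known", "first", "only" and "open" are said of these compounds alone.

In an ADME assay on MRC5 cells (Homo sapiens) for cytotoxicity, read by MTT assay, with a stated time of 6 days (a higher number here means a weaker inhibitor, a lower number a stronger inhibitor), compound 1 `CC(=O)O[C@@H]1C=CC(=O)O[C@@H]1[C@@H](COC(=O)c1ccc(Cl)cc1)OC(C)=O` gives > 100000 nM, which is a limit of the assay and not a number. Compound 3 `COc1ccc(/C=C/C(=O)OC[C@@H](OC(C)=O)[C@H]2OC(=O)C=C[C@H]2OC(C)=O)cc1` keeps the shared core and has 2-(4-methoxyphenyl)ethenyl in place of 4-chlorophenyl on a carbonyl carbon. Compound 2 `COc1ccc(/C=C/C(=O)OC[C@@H](OCc2ccccc2)[C@H]2OC(=O)C=C[C@H]2OCc2ccccc2)cc1`, which also carries 2-(4-methoxyphenyl)ethenyl, gives > 100000 nM, also a limit, so no step beyond the usual scatter is expected in this assay. The estimated change is a number no higher from compound 1 to compound 3 (the limit leaves the size open). For compound 3 the expected value is 100000 nM, with an estimated range from 40000 nM to 200000 nM.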

Compound 3, half-maximal inhibitory concentration: 78000 nM
For compound 3 the middle estimate is 1.3-fold (0.11 log units) above the measured one; the range from low to high includes it.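

Among the compounds shown here, with compound 3, this position on a carbonyl carbon gives a real number in this assay for the first time, not just a limit. Replacing 4-chlorophenyl with 2-(4-methoxyphenyl)ethenyl gives an at least 1.2-fold lower number from compound 1 to compound 3 (0.10 log units; that floor lies within the scatter). The full size of this step stays unknown because compound 1 sits at a limit: the limit of > 100000 nM in this assay, at which 2 of the 3 values shown sit.

The compounds shown leave open whether a different group in this place, such as a phenyl ring carrying an amine or a longer carbon chain, would move the number further.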